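Swapping the triazole substituent: from hydroxypropyl to fluorophenyl

A few compounds are considered here, and "the series" means these few. Any claim that something is new, unique, unknown or untested is made for them only; others in the source may bear on it.

Of the compounds shown here, three sharing one core have been tested in an ADME assay on PC-3 cells (Homo sapiens) for cytotoxicity, read by sulforhodamine B assay, with a stated time of 48 h, tested at 10 uM; on this read-out lower numbers stand for less inhibition and higher numbers for more inhibition at the one concentration tested (going by the name of the read-out). Compound 1, with structure `COc1nc2ccc(Br)cc2cc1C(c1ccccc1)n1cc(-c2ccc(Br)cc2)nn1`, gives 7.43%. Compound 2, with structure `COc1nc2ccc(Br)cc2cc1C(c1ccccc1)n1cc(-c2ccccc2F)nn1`, gives 13.4%. Compound 3, with structure `COc1nc2ccc(Br)cc2cc1C(c1ccccc1)n1cc(CCCO)nn1`, gives 14.7%. Compound 3 is the reference point here; the two neighbouring numbers sit close to it, since the step of a number 7.3 percentage points higher from compound 1 to compound 3 (within the scatter) and the step of a number 1.3 percentage points higher from compound 2 to compound 3 (within the scatter) both lie within the scatter, as does the step of a number 6 percentage points higher from compound 1 to compound 2 (within the scatter). On these numbers none of the three compounds can be set apart from the others.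

Compound 4, with structure `COc1nc2ccc(Br)cc2cc1C(c1ccccc1)n1cc(-c2ccc(F)cc2)nn1`, is not yet measured. It differs from compound 3 in one place: 4-fluorophenyl in place of 3-hydroxypropyl on an aromatic carbon. Among the measured compounds shown here, the steps that bear on this change are those in which an aryl group on the same aromatic carbon was traded for the 3-hydroxypropyl chain, namely the step from compound 1 to compound 3 and the step from compound 2 to compound 3. Both were small and within the scatter. Reversing that kind of exchange is therefore expected to give at most a small movement in this assay, if anything slightly downward, and the step of a number 4.7 percentage points lower from compound 3 to compound 4 (within the scatter) is expected to stay within the scatter. Compound 4 is estimated to give 10%, within a range from 2% to 20%.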

Compound 4, a percentage reported as inhibition, at one concentration (the size of the read-out at that concentration, not a potency): 16.4%
Beside the measured number, compound 4's estimate is 6.4 percentage points below it; low and high end bracket the measured number.
By their numbers in this assay, from the lowest: compounds 1, 2, 3 and 4 (each within the scatter of the next).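

In this assay, replacing the chain with an aromatic ring gives a number 1.7 percentage points higher from compound 3 to compound 4 (within the scatter) and so, at this carbon of the five-membered aromatic ring with 3 nitrogen, a 4-fluorophenyl group cannot be told apart from a 3-hydroxypropyl group, even though the chain's hydrogen-bond donor and acceptor are gone. The fluorine's place on the aromatic ring also makes no readable difference, as 4-fluorophenyl in place of 2-fluorophenyl gives a number 3 percentage points higher from compound 2 to compound 4 (within the scatter) in the same read-out. The halogen at the same ring place behaves likewise, since fluoro in place of bromo gives a number 9 percentage points higher from compound 1 to compound 4 (within the scatter) and thus the four groups now seen at this carbon cannot be separated in this assay.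

As far as these compounds go, whether an amine, a carboxylic acid or a longer chain at this carbon would move the number beyond the scatter remains open. Nothing available explains why these groups read alike, and no supporting measurement bears on this result.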